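The compounds below may be only part of what the source reports. "The series", "measured", "known", "first", "only" and "open" are said of these compounds alone.

Working notes on the series, benzyl-bearing triazole compounds. Among the measured compounds shown here, in a functional assay on Bel-7402 cells (Homo sapiens) for antiproliferative activity, read by MTT assay, with a stated time of 72 h (on this read-out lower numbers stand for stronger inhibition and higher numbers for weaker inhibition), compound 3 `C=C1C(=O)O[C@H]2[C@H]1CC/C(Cn1cc(Cn3cc(F)c(=O)n(Cc4ccccc4)c3=O)nn1)=C\CC[C@@]1(C)O[C@@H]21` gives 9160 nM, the higher of the two true numbers so far, the other being compound 2 `C=C1C(=O)O[C@H]2[C@H]1CC/C(COC(=O)Cn1cc(F)c(=O)n(Cc3ccccc3)c1=O)=C\CC[C@@]1(C)O[C@@H]21` at 3980 nM. In this assay, compound 1 `C=C1C(=O)O[C@H]2[C@H]1CC/C(Cn1cc(Cn3cc(F)c(=O)[nH]c3=O)nn1)=C\CC[C@@]1(C)O[C@@H]21` gives > 20000 nM, which is a limit and not a number.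

Compound 4 `C=C1C(=O)O[C@H]2[C@H]1CC/C(Cn1cc(Cn3cc(F)c(=O)n(Cc4ccc(F)cc4)c3=O)nn1)=C\CC[C@@]1(C)O[C@@H]21` differs from compound 3 in one place: fluoro in place of hydrogen on an aromatic carbon. In words, this is fluoro in place of hydrogen on an aromatic carbon, para to a large group, so benzyl becomes 4-fluorobenzyl.

For the measured compounds named here, only one measured step bears on this, and only indirectly. Adding the benzyl itself gave an at least 2.1-fold lower number from compound 1 to compound 3 (0.33 log units; beyond the scatter). That step rests on (the limit of > 20000 nM in this assay, at which 1 of the 3 values shown sits). Going by the values given here, no measured step changes a substituent on the benzyl ring, so the size of this change has no direct precedent.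

With compound 3 at 9160 nM as the starting point and the step of an at least 2.1-fold lower number from compound 1 to compound 3 (0.33 log units; beyond the scatter) concerning the whole benzyl rather than one ring hydrogen, no step beyond the scatter is expected in this assay. The estimated step is a 1.1-fold lower number from compound 3 to compound 4 (0.06 log units; within the scatter). For compound 4 the expected value is 8000 nM, with an estimated range of 3500 nM to 18000 nM.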

Compound 4, half-maximal inhibitory concentration: 4910 nM
The estimate for compound 4 lay 1.6-fold (0.21 log units) above the measured number, within the range that was stated.
By their numbers in this assay, from the lowest: compounds 2, 4 and 3 (each within the scatter of the next, the first and the last beyond it). At a limit, above all of these: compound 1.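

Among the compounds shown here, compound 4 is the first measured case of a substituent on the benzyl ring itself, and in this assay fluoro in place of hydrogen, para to a large group, gives a 1.9-fold lower number from compound 3 to compound 4 (0.27 log units; within the scatter) and so no step that stands clear of the scatter. The 4-fluorobenzyl in place of hydrogen on the aromatic nitrogen gives an at least 4.0-fold lower number from compound 1 to compound 4 (0.60 log units; beyond the scatter) and thus extends the step seen with the plain benzyl to a second compound, so the gain from a group on that nitrogen no longer hangs on compound 3 alone. Compound 1 stands at a limit and not at a number, so the true size of this step cannot be read: the limit of > 20000 nM in this assay, at which 1 of the 4 values shown sits.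

From the compounds shown here alone, what a larger group in the same place on the ring, such as methoxy, trifluoromethyl or an amine, would do to the number remains open, and a single fluoro gives no trend across the ring. Also open, going by these compounds, is whether 4-fluorobenzyl would behave the same way on the ester-linked compound 2, which carries the plain benzyl.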